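The compounds below may be only part of what the source reports. "The series", "measured", "known", "first", "only" and "open" are said of these compounds alone.

Measured so far in a functional assay on K562 cells (Homo sapiens) for inhibition, read by trypan blue exclusion, with a stated time of 72 h; on this read-out lower numbers stand for stronger inhibition and higher numbers for weaker inhibition:
- compound 1 `Cn1c(=O)c(S(=O)(=O)c2ccc(F)cc2)cc2cnc(Nc3ccc4[nH]ccc4c3)nc21`: 200 nM
- compound 2 `Cn1c(=O)c(S(=O)(=O)c2ccc(F)cc2)cc2cnc(Nc3ccc4[nH]cnc4c3)nc21`: 10000 nM
- compound 3 `Cn1c(=O)c(S(=O)(=O)c2ccc(F)cc2)cc2cnc(Nc3cccc4[nH]ccc34)nc21`: 750 nM

Compound 3 holds the middle place of these three numbers, with compound 1 lower and compound 2 higher. Next in this assay is compound 4 `Cn1c(=O)c(S(=O)(=O)c2ccc(F)cc2)cc2cnc(Nc3cnc4[nH]ccc4c3)nc21`, which differs from compound 3 by a group of 9 heavy atoms (7 carbon, 2 nitrogen; one five-membered aromatic ring with 1 hetero atom, one six-membered aromatic ring with 1 hetero atom) in place of a group of 9 heavy atoms (8 carbon, 1 nitrogen; one five-membered aromatic ring with 1 hetero atom, one six-membered aromatic ring of carbon only), on a nitrogen on an aromatic ring. The six-membered aromatic ring thus gains a hetero atom.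

Going by the values given here, no measured step makes this exact change. Among the compounds with values here, the closest precedent is 1H-benzimidazol-5-yl in place of 1H-indol-5-yl, which gave a 50-fold higher number from compound 1 to compound 2 (1.70 log units; beyond the scatter), a large step. The large 13-fold lower number from compound 2 to compound 3 (1.12 log units; beyond the scatter) points the same way. The modest 3.8-fold higher number from compound 1 to compound 3 (0.57 log units; beyond the scatter) shows a smaller effect between the two indolyl groups. Compound 2 carries its added hetero atom in the other ring, so only part of its large step is expected to carry over.

The expected change is a 2.1-fold higher number from compound 3 to compound 4 (0.33 log units; beyond the scatter), a modest step towards a higher number.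

For compound 4 the estimated value is 1600 nM, with an expected range of 300 nM to 8000 nM.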

Compound 4, half-maximal inhibitory concentration: 750 nM
Compound 4: the middle estimate sits 2.1-fold (0.33 log units) above what was measured; measured number inside the range.
By their numbers in this assay, from the lowest: compound 1; then compounds 3 and 4 (each within the scatter of the next); then compound 2.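

In this assay, a hetero atom in the six-membered aromatic ring of the group on a nitrogen on an aromatic ring gives no change at the digits printed from compound 3 to compound 4 (within the scatter), so this change leaves the read-out within the scatter. The location of the added hetero atom matters in this small set: moving from 1H-benzimidazol-5-yl to the new group, which carries its added hetero atom in the six-membered aromatic ring, gives a 13-fold lower number from compound 2 to compound 4 (1.12 log units; beyond the scatter). The new group still does not match 1H-indol-5-yl, with a 3.8-fold higher number from compound 1 to compound 4 (0.57 log units; beyond the scatter) in this assay.

The data shown offer no measurement that accounts for these differences. Open, going by these compounds, is how the read-out would respond to an amine or a carboxylic acid on the 1H-indol-5-yl group of compound 1.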